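What rearranging the chlorines may do to compound 4

The source may hold more compounds than are shown below. What is called first, only, known or untested is meant among the compounds shown, and "the series" means these compounds.

Measured in an ADME assay on MT4 cells (Homo sapiens) for cytotoxicity, read by MTT assay; on this read-out lower numbers stand for higher toxicity in this test and higher numbers for lower toxicity in this test:
- compound 1 `O=C1c2ccccc2C(=O)N1CCOC(=S)N(C(=O)c1ccc(C(F)(F)F)cc1)c1ccc(Cl)cc1`: 10000 nM
- compound 2 `O=C1c2ccccc2C(=O)N1CCOC(=S)N(C(=O)c1cc(F)cc(F)c1)c1ccc(Cl)cc1`: 59000 nM
- compound 3 `O=C1c2ccccc2C(=O)N1CCOC(=S)N(C(=O)c1ccc(Cl)cc1Cl)c1ccc(Cl)cc1`: 18000 nM

Among the measured compounds shown here, of the three numbers, the one for compound 3 sits nearer the lower end. The steps that place it are a 1.8-fold higher number from compound 1 to compound 3 (0.26 log units; within the scatter) and a 3.3-fold lower number from compound 2 to compound 3 (0.52 log units; beyond the scatter).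

Compound 4 `O=C1c2ccccc2C(=O)N1CCOC(=S)N(C(=O)c1c(Cl)cccc1Cl)c1ccc(Cl)cc1` has the same atoms as compound 3, joined differently: 2,6-dichlorophenyl in place of 2,4-dichlorophenyl on a carbonyl carbon. That is, 2,6-dichlorophenyl in place of 2,4-dichlorophenyl on a carbonyl carbon.

All measured steps swap the group at this same place, and the largest is a 5.9-fold higher number from compound 1 to compound 2 (0.77 log units; beyond the scatter). For the measured compounds named here, no measured compound carries 2,6-dichlorophenyl, so none shows this change directly. A step of that size stays possible, but no step beyond the scatter is expected in this assay, and no direction can be favoured. The expected step is a 1.1-fold higher number from compound 3 to compound 4 (0.05 log units; within the scatter). Compound 4 is estimated at 20000 nM, with an expected range of 8000 nM to 50000 nM.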

Compound 4, half-maximal cytotoxic concentration: 20000 nM
The estimate for compound 4 equals the measured number at the digits printed; the measured number falls inside the stated range.
By their numbers in this assay, from the lowest: compounds 1, 3 and 4 (each within the scatter of the next); then compound 2.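

In this assay, moving one chlorine of the dichlorophenyl group on the carbonyl carbon changes little (a 1.1-fold higher number from compound 3 to compound 4 (0.05 log units; within the scatter)), so at this place the two arrangements of chlorine cannot be told apart. The step from the 4-(trifluoromethyl)phenyl compound also stays small (a 2.0-fold higher number from compound 1 to compound 4 (0.30 log units; within the scatter)), whereas 3,5-difluorophenyl remains apart from the 2,6-dichlorophenyl compound (a 3.0-fold lower number from compound 2 to compound 4 (0.47 log units; beyond the scatter)). Nothing available explains these numbers. Still open, from the compounds shown here alone, is whether a phenyl ring carrying an amine or a carboxylic acid would shift the number. Also open, going by these compounds, is how other arrangements of fluorine would compare with 3,5-difluorophenyl.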